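Working notes: aryl amide change from compound 1 to compound 3

The source may report more compounds than this note shows. Statements on the series, on what has been measured and on what is new or still open speak of the compounds shown alone.

Measured compounds:
compound 1 `O=C(c1ccc(Cl)cc1)N1CC(c2nc(-c3cccc(F)c3)no2)C1`, in an assay on HEK293 cells for positive allosteric modulation of metabotropic glutamate receptor 5 (Homo sapiens), read by FLIPR (a higher number here means that more compound is needed for the effect, a lower number that less compound is needed), compound 1 gives 2500 nM
compound 2 `Cc1cccc(S(=O)(=O)N2CC(c3nc(-c4cccc(Cl)c4)no3)C2)c1`, in this assay compound 2 gives > 10000 nM

Going by the values given here, compound 1 holds the only numerical value in this assay. The result for compound 2 is a limit of this assay, not a number; it sits at the limit of > 10000 nM in this assay, at which 1 of the 2 values shown sits.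

Compound 3 `O=C(c1ccc(F)c(F)c1)N1CC(c2nc(-c3cccc(F)c3)no2)C1` is not yet measured. It differs from compound 1 by 3,4-difluorophenyl in place of 4-chlorophenyl on a carbonyl carbon. Among the compounds with values here, no measured pair in this set shows the effect of such a change, so the step is expected to be small: from compound 1 to compound 3 a step of a 1.2-fold higher number from compound 1 to compound 3 (0.08 log units; within the scatter) is estimated, within or close to the usual scatter. For compound 3 the expected value in this assay is 3000 nM, with a range from 800 nM to 12000 nM.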

Compound 3, half-maximal effective concentration: 3200 nM
For compound 3 the middle estimate is 1.1-fold (0.03 log units) below the measured one; the measured number falls inside the stated range.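

With a 1.3-fold higher number from compound 1 to compound 3 (0.11 log units; within the scatter), the amide on the shared core gains its first measured pair in this assay. At this position on a carbonyl carbon, 3,4-difluorophenyl and 4-chlorophenyl are not told apart by this result. No measured evidence shown bears on why the two groups read alike.

Going by these compounds, whether an aminomethyl or a carboxylic acid on the phenyl ring, or a saturated ring in its place, would give a step beyond the scatter remains open. Compound 2 stays a limit of this assay at > 10000 nM and differs from compound 1 in more than one place, which leaves the sulfonyl link without a comparison.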